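Replacing the acetyl of compound 2

A few compounds are considered here, and "the series" means these few. Any claim that something is new, unique, unknown or untested is made for them only; others in the source may bear on it.

In an ADME assay (liver) for metabolic stability, with Liver microsome (Rattus norvegicus) as the target, using microsomes and NADPH, with a stated time of 30 min (on this read-out higher numbers stand for fast clearance and lower numbers for slow clearance), compound 1 `CC#C[C@H]1CN(S(=O)(=O)c2ccc(N)nc2)CCN1c1ccc(S(=O)(=O)NCC2CC2)cc1` gives 213 mL.min-1.g-1 and compound 2 `CC#C[C@H]1CN(S(=O)(=O)c2ccc(N)nc2)CCN1c1ccc(C(C)=O)cc1` gives 249 mL.min-1.g-1, two values within the usual scatter of each other. Compound 2 therefore does not stand apart on these numbers. Compound 3 `CC#C[C@H]1CN(S(=O)(=O)c2ccc(N)nc2)CCN1c1ccc([S+](C)[O-])cc1` keeps the shared core of compound 2 and changes one group: a group of 3 heavy atoms (1 carbon, 1 oxygen, 1 sulfur; no ring) in place of a group of 3 heavy atoms (2 carbon, 1 oxygen; no ring), on an aromatic carbon. The acetyl leaves an aromatic carbon of a six-membered aromatic ring of carbon only, para to a large group, and the new group takes its place there.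

Within the data shown here, only one measured step bears on this change, at that same carbon: acetyl in place of (cyclopropylmethyl)sulfamoyl, which is a 1.2-fold higher number from compound 1 to compound 2 (0.07 log units; within the scatter). Going by that one small step, no step beyond the scatter is expected for compound 3 in this assay. Among the measured compounds shown here, no measured compound carries the entering group, so the direction is only weakly held. The estimated step is a 1.3-fold lower number from compound 2 to compound 3 (0.12 log units; within the scatter). For compound 3 the expected value is 190 mL.min-1.g-1, with an estimated range from 90 mL.min-1.g-1 to 340 mL.min-1.g-1.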

Compound 3, intrinsic clearance in microsomes: 17 mL.min-1.g-1
The estimate for compound 3 lay 11-fold (1.05 log units) above the measured number, and the stated range ends above it.
By their numbers in this assay, from the lowest: compound 3; then compounds 1 and 2 (each within the scatter of the next).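

In this assay, among these compounds, the aromatic carbon para to a large group turns out to be able to move the read-out a long way: there is a 15-fold lower number from compound 2 to compound 3 (1.17 log units; beyond the scatter), and a 13-fold lower number from compound 1 to compound 3 (1.10 log units; beyond the scatter), whereas the only earlier step at this carbon, a 1.2-fold higher number from compound 1 to compound 2 (0.07 log units; within the scatter), stayed within the scatter. Acetyl and (cyclopropylmethyl)sulfamoyl differ widely in size yet sit together at the fast-clearance end, so among the three compounds the group of 3 heavy atoms (1 carbon, 1 oxygen, 1 sulfur; no ring) alone stands apart. That group matches acetyl in its count of heavy atoms and of hydrogen-bond acceptors, so neither count separates compound 3 from compound 2. Nothing among the data shown accounts for this gap.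

Only three groups at this carbon are shown, all on the same shared core, so it stays open whether the low number is particular to the entering group or would carry over to another core. As far as these compounds go, how a methylsulfonyl, a nitrile or an amine at that aromatic carbon would read in this assay also remains open.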